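Esterifying the Hydroxy Group of a Weakly Active Lactone

This account rests on a few compounds, and the source may have more. Where it says the series, first, only, none or still open, it means among the compounds named here.

Compound 3 `C=C1CC[C@H]2[C@@](C)(CC[C@@H](O)[C@@]2(C)NC=O)[C@@H]1/C=C/C1=CCOC1=O` was tested in an assay for inhibition of hexokinase-2 (Homo sapiens), read by coupled enzyme assay, with a stated time of 10 min, in the presence of a further agent that is not named here; on this read-out lower numbers stand for stronger inhibition and higher numbers for weaker inhibition. In this assay compound 3 gives only a limit of the assay, > 50000 nM, and no number. Two related compounds stand the same way. In this assay compound 1 `C=C1CC[C@H]2[C@@](C)(CCC(=O)N[C@@]2(C)CO)[C@@H]1/C=C/C1=CCOC1=O` gives > 50000 nM, a limit. In this assay compound 2 `C=C1CC[C@H]2[C@@](C)(CCC(=O)N[C@@]2(C)COC(=O)c2ccc([N+](=O)[O-])cc2)[C@@H]1/C=C/C1=CCOC1=O` gives > 50000 nM, also a limit. All three values sit on one line: the limit of > 50000 nM in this assay, at which 3 of the 3 values shown sit.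

Compound 4 `C=C1CC[C@H]2[C@@](C)(CC[C@@H](OC(=O)c3ccc([N+](=O)[O-])cc3)[C@@]2(C)NC=O)[C@@H]1/C=C/C1=CCOC1=O` differs from compound 3 in one place: (4-nitrophenyl)carbonyl in place of hydrogen on an oxygen on a saturated carbon. For the measured compounds named here, the only measured comparison of the same kind is the step that the two limits leave unreadable from compound 1 to compound 2, in which the same group is added to a hydroxy on the core of compound 1. Both ends of that step are limits, so its size and direction cannot be read. Going by the values given here, no measured step therefore shows whether this change helps or hurts in this assay.

Compound 4 is expected to remain a limit as well, with an estimate of 60000 nM, ranging from 15000 nM to 300000 nM. The step this estimate implies is expected to be a step that the limit leaves unreadable from compound 3 to compound 4.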

Compound 4, half-maximal inhibitory concentration: > 50000 nM
Compound 4 gave a limit, no number; the forecaster's own chance of this, stated with the estimate: 85%; the middle value is on the limit's open side.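

Compound 3 and compound 4 both give only a limit in this assay, and the step between them cannot be read in size or direction. The compounds shown leave open whether adding (4-nitrophenyl)carbonyl, or any other change to these structures, alters inhibition at all.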